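The source may report more compounds than this note shows. Statements on the series, on what has been measured and on what is new or still open speak of the compounds shown alone.

Measured compounds:
- compound 1, `CCCCCCCCCCOc1ccc(-c2c(C)[nH]c(=O)n2C2CCCCC2)cc1`, with 0.1 mg/kg
- compound 2, `Cc1[nH]c(=O)n(C2CCCCC2)c1-c1ccc(-c2ccccc2)cc1`, with 0.1 mg/kg

Both compounds were tested in a functional assay on the whole organism with Rattus norvegicus as the target; a lower number here means that less compound is needed, a higher number that more compound is needed for the effect. Compound 1 needs 0.1 mg/kg and compound 2 needs 0.1 mg/kg; on the digits reported the two stand level, and the nearest neighbour of compound 2 is compound 1, with no change between them beyond the usual scatter. The two compounds share a common core and differ only in the group carried on the outer benzene ring, yet they need the same dose.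

Compound 3, `Cc1[nH]c(=O)n(C2CCCCC2)c1-c1ccc(OCc2ccccc2)cc1`, has not yet been tested. It differs from compound 2 in one place: benzyloxy in place of phenyl on an aromatic carbon. The group that leaves and the group that enters each bring one six-membered aromatic ring of carbon only, and the entering benzyloxy adds one oxygen as a hydrogen-bond acceptor. Among the measured compounds shown here, no step between two measured compounds mirrors this change, so the data give no measured size for it. Given that compound 1 and compound 2 carry different groups at this place, and that compound 1 still gives 0.1 mg/kg while compound 2 gives 0.1 mg/kg, the expected step is small or none beyond the scatter, perhaps leaning toward a slightly higher dose. For compound 3 the expected step from compound 2 is a 1.5-fold higher number from compound 2 to compound 3 (0.18 log units; within the scatter). Compound 3 is estimated at 0.15 mg/kg in this assay, with a range from 0.05 mg/kg to 0.5 mg/kg.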

Compound 3, minimum effective dose: 0.1 mg/kg
Estimate against measurement, compound 3: 1.5-fold (0.18 log units) above; measured number inside the range.
By their numbers in this assay, from the lowest: compounds 1, 2 and 3 (each within the scatter of the next).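

In this assay, putting benzyloxy in place of phenyl on an aromatic carbon, para to a large group, gives no change at the digits printed from compound 2 to compound 3 (within the scatter) and so shows directly that this place accepts the entering oxygen and the larger group with no visible shift in dose. Phenyl in place of nonyl on a saturated chain carbon bound to an oxygen on an aromatic ring gives no change at the digits printed from compound 1 to compound 3 (within the scatter) as a second readable step at the same place. With the oxygen kept, the group can therefore end either in a long chain or in a six-membered aromatic ring of carbon only, and the three compounds still stand level. Nothing at hand explains why the dose stays level across these groups.

On these data alone, it remains open whether a group of a different kind at this place, such as an amine or a carboxylic acid, or a small one such as methyl, would keep the dose level. All three compounds stand at the same printed level, so the shown steps give no sign of which change at this place, if any, would move the dose beyond the scatter.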